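A few compounds are considered here, and "the series" means these few. Any claim that something is new, unique, unknown or untested is made for them only; others in the source may bear on it.

Measured so far:
- compound 1 `COC(=O)C1=C(C)N=C(C)/C(=C(/O)OC)C1c1c(F)cccc1Cl`: 7.59 nM
- compound 2 `COC(=O)C1=C(C)N=C(C)/C(=C(\O)OC)C1c1cc(Cl)cc(Cl)c1`: 93.3 nM
- compound 3 `COC(=O)C1=C(C)N=C(C)/C(=C(\O)OC)C1c1c(F)c(F)c(F)c(F)c1F`: 4.37 nM

All three compounds share the same core and were tested in a functional assay (muscle tissue) with Cavia porcellus as the target; a higher number here means that more compound is needed for the effect, a lower number that less compound is needed. Compound 2 stands at the high end of these three numbers: compound 1 sits well below it, and compound 3 sits lower still, both gaps being clearly beyond the usual scatter. Among the compounds with values here, no step between two compounds that differ in a single place has been worked out here, so only the numbers themselves can be compared.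

Compound 4 `COC(=O)C1=C(C)N=C(C)/C(=C(\O)OC)C1c1ccccc1F` has not yet been measured. It differs from compound 2 in one place:

2-fluorophenyl in place of 3,5-dichlorophenyl on a saturated ring carbon

Compound 1 and compound 3, which both carry fluorine-bearing phenyl groups on that saturated ring carbon, give much lower numbers than compound 2 with its 3,5-dichlorophenyl. Within the data shown here, on that basis the step from compound 2 to compound 4 is expected to go downward, by a margin beyond the scatter, though with only two comparison points the size is uncertain. The expected step is a 6.2-fold lower number from compound 2 to compound 4 (0.79 log units; beyond the scatter). For compound 4 the expected value in this assay is 15 nM, with a range from 4 nM to 60 nM.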

Compound 4, half-maximal effective concentration: 42.7 nM
Compound 4: the middle estimate sits 2.8-fold (0.45 log units) below what was measured, and the stated range covers the measured number.
By their numbers in this assay, from the lowest: compounds 3 and 1 (each within the scatter of the next); then compound 4; then compound 2.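

In this assay, within the data shown here, the change to 2-fluorophenyl in place of 3,5-dichlorophenyl on the saturated ring carbon gives a 2.2-fold lower number from compound 2 to compound 4 (0.34 log units; beyond the scatter) while the rest of the molecule stays the same, so this is the first direct reading of what this position contributes. The step is modest but beyond the scatter, which shows that the number responds to the halogens on this phenyl ring even though both groups share the same aromatic ring, carry no net charge and have no hydrogen-bond donors or acceptors. Two chlorines leave and one fluorine enters at a different place on the ring, all in a single step, and no measurement given here accounts for the shift.

The compounds shown leave open whether the kind of halogen, the number of halogens or their place on the ring matters most, a question that 2-chlorophenyl or 3,5-difluorophenyl at this carbon would help to separate. They also leave open how plain phenyl, with no halogen at all, or a phenyl bearing a methoxy group would compare with compound 4 at this position.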